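A few compounds are considered here, and "the series" means these few. Any claim that something is new, unique, unknown or untested is made for them only; others in the source may bear on it.

Measured so far:
compound 1, `O=C(CCCCC1CCSS1)Nc1ccc(OC(F)(F)F)cc1`, 84.5%
compound 2, `O=C(CCCCC1CCSS1)Nc1cccc2ccccc12`, "not active" (no number reported)
compound 3, `O=C(CCCCC(S)CCS)Nc1ccc(OC(F)(F)F)cc1`, 66.8%

All three were tested in a functional assay on HO8910 cells (Homo sapiens) for inhibition, read by MTT assay, with a stated time of 24 h, tested at 100 ug/mL; a lower number here means less inhibition of growth, a higher number more inhibition of growth at the concentration tested. Compound 1 carries the five-membered ring bearing two sulfur atoms and gives 84.5%. Compound 3 is the ring-opened counterpart of compound 1, the change being (a group of 5 heavy atoms (3 carbon, 2 sulfur; no ring) in place of a group of 5 heavy atoms (3 carbon, 2 sulfur; one five-membered non-aromatic ring with 2 hetero atoms), on a saturated chain carbon, four bonds along the chain from a carbonyl carbon); in this assay compound 3 gives 66.8%. The step of a number 17.7 percentage points lower from compound 1 to compound 3 (beyond the scatter) lies beyond the scatter, so opening the ring to the 1,3-disulfanylpropyl group cost some growth inhibition on this core.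

Compound 2 shares the closed ring with compound 1 but carries a different core; the difference between the two cores is not broken down here. For compound 2 the assay reported no number, only that it was not active at the concentration tested.

Compound 4, `O=C(CCCCC(S)CCS)Nc1cccc2ccccc12`, is not yet measured. It stands to compound 2 exactly as compound 3 stands to compound 1: the change is a group of 5 heavy atoms (3 carbon, 2 sulfur; no ring) in place of a group of 5 heavy atoms (3 carbon, 2 sulfur; one five-membered non-aromatic ring with 2 hetero atoms), on a saturated chain carbon, four bonds along the chain from a carbonyl carbon, the same change at the same place. For the measured compounds named here, since compound 2 already gave no measurable inhibition, and since the one measured instance of this change lowered inhibition, as seen in a number 17.7 percentage points lower from compound 1 to compound 3 (beyond the scatter), compound 4 is expected to show little or no growth inhibition as well. The step from compound 2 cannot be sized: compound 2 has no number. Compound 4 is estimated at 8% in this assay, with an expected range from 0% to 30%, and a real chance that only "not active" is reported again.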

Compound 4, percent growth inhibition at one concentration: "not active" (no number reported)
The entry for compound 4 holds no number, and the estimate cannot be compared.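

In this assay, for the compounds shown here, compound 4 is reported only as "not active", as is compound 2, so no step from compound 2 to compound 4 can be read. The compounds shown leave open whether the 1,3-disulfanylpropyl group in place of the closed ring changes growth inhibition at all on the core of compound 2. No measured property bears on this result.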